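Swapping the aryl cap on a piperazine: chloro for cyanopyridyl

The source may hold more compounds than are shown below. What is called first, only, known or untested is meant among the compounds shown, and "the series" means these compounds.

Measured compounds:
compound 1 `O=C([C@@H]1C[C@H](N2CCN(c3ccccn3)CC2)CN1)N1CCSC1` gives 3.5 nM
compound 2 `COc1ccc(N2CCN([C@@H]3CN[C@H](C(=O)N4CCSC4)C3)CC2)cc1` gives 16.9 nM
compound 3 `N#Cc1ccnc(N2CCN([C@@H]3CN[C@H](C(=O)N4CCSC4)C3)CC2)c1` gives 1.9 nM

In an assay on a cell-free system (plasma) for inhibition of Dipeptidyl peptidase 4 (Rattus norvegicus), read by fluorescence (on this read-out lower numbers stand for stronger inhibition and higher numbers for weaker inhibition), compound 3 gives the lowest number of the three. Its nearest neighbour is compound 1, and that gap, a 1.8-fold lower number from compound 1 to compound 3 (0.27 log units; within the scatter), is within the scatter. Compound 2 sits furthest away, a gap of an 8.9-fold lower number from compound 2 to compound 3 (0.95 log units; beyond the scatter) that is beyond the scatter.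

Compound 4 `O=C([C@@H]1C[C@H](N2CCN(c3cccc(Cl)c3)CC2)CN1)N1CCSC1` has not yet been measured. It differs from compound 3 in one place: 3-chlorophenyl in place of 4-cyanopyridin-2-yl on an amine nitrogen in a ring.

Among the compounds with values here, two measured steps bear on this change, both replacing the aryl group on the same ring nitrogen. From compound 1 to compound 2 the number rose by a 4.8-fold higher number from compound 1 to compound 2 (0.68 log units; beyond the scatter), and from compound 2 to compound 3 it fell by an 8.9-fold lower number from compound 2 to compound 3 (0.95 log units; beyond the scatter). Compound 4 carries a carbon-only ring, as compound 2 does, without the cyano group or the ring nitrogen of compound 3. A rise in the number is therefore expected for compound 4, of roughly a 5.3-fold higher number from compound 3 to compound 4 (0.72 log units; beyond the scatter), giving an estimated 10 nM with a range from 4 nM to 30 nM.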

Compound 4, half-maximal inhibitory concentration: 7.2 nM
Beside the measured number, compound 4's estimate is 1.4-fold (0.14 log units) above it; low and high end bracket the measured number.
By their numbers in this assay, from the lowest: compounds 3 and 1 (each within the scatter of the next); then compound 4; then compound 2.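

In this assay, the change shows that a carbon-only ring on this amine nitrogen in a ring does not fix the number, since the substituent on that ring also counts: a 2.3-fold lower number from compound 2 to compound 4 (0.37 log units; beyond the scatter). Even so, 3-chlorophenyl stays behind both pyridine-bearing groups, with a 3.8-fold higher number from compound 3 to compound 4 (0.58 log units; beyond the scatter) and a 2.1-fold higher number from compound 1 to compound 4 (0.31 log units; beyond the scatter), both beyond the scatter though modest. Across these four compounds, both carbon-only rings therefore give higher numbers than both pyridine rings, and no compound shown goes against this.

Nothing measured here gives a reason for these gaps. From the compounds shown here alone, it also stays open whether the gap between the two carbon-only rings comes from the kind of substituent or from where it sits, and a pyridin-2-yl carrying chloro, or a phenyl carrying an amine, would bear on that.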